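The compounds below may be only part of what the source reports. "The series", "measured", "known", "first", "only" and "open" are said of these compounds alone.

Of the compounds shown here, three have so far been tested in a functional assay on LM7 cells (Homo sapiens) for antiproliferative activity, read by MTT assay, with a stated time of 72 h; on this read-out higher numbers stand for weaker inhibition and lower numbers for stronger inhibition. Compound 1 `O=c1c(SC(=S)N2CCCC2)coc2ccc(Cl)cc12` gives 24600 nM in this assay. Compound 2 `O=c1c(SC(=S)N2CCCCC2)coc2ccccc12` gives 7800 nM, and compound 3 `O=c1c(CSC(=S)N2CCCC2)coc2ccccc12` gives 6000 nM. Among these three numbers, compound 2 stands second highest: its number and that of compound 3 lie within the usual scatter of each other, so nothing separates them, while compound 1 shows a number clearly higher than that of compound 2, beyond the scatter.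

Compound 4 `O=c1c(SC(=S)N2CCCCC2)coc2ccc(Cl)cc12` has not yet been measured. It is derived from compound 2 by a single change: chloro in place of hydrogen on an aromatic carbon. Among the compounds with values here, no pair of measured compounds differs by exactly this change, so the size of the step has to be judged indirectly. Within the data shown here, compound 1, the only measured compound carrying a chloro group, gives the highest number of the three with 24600 nM, but it differs from compound 2 in more than one place, so it serves only as a weak hint. The expected step is therefore a modest one, leaning toward a higher number, a 1.5-fold higher number from compound 2 to compound 4 (0.19 log units; within the scatter). On that basis compound 4 is expected to give about 12000 nM in this assay, with a likely range from 5000 nM to 30000 nM.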

Compound 4, half-maximal inhibitory concentration: > 25000 nM
Compound 4 ended at the assay's limit; the forecaster's own chance of this, stated with the estimate: 5%; at least 2.0-fold (0.31 log units) between middle value and limit.
By their numbers in this assay, from the lowest: compounds 3 and 2 (each within the scatter of the next); then compound 1. At a limit, above all of these: compound 4.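

In this assay compound 4 gives > 25000 nM as a limit of the assay and not a number. Within the data shown here, this gives the first direct reading of chloro in place of hydrogen on this aromatic carbon, meta to a fused ring and para to a fused ring: the one pair that differs by this change shows an at least 3.2-fold higher number from compound 2 to compound 4 (0.50 log units; beyond the scatter) and so a loss of inhibition that is at least modest, which the earlier compounds could only hint at. How much further the true step reaches stays unknown because the reading stops at a limit: the limit of > 25000 nM in this assay, at which 1 of the 4 values shown sits.

Piperidin-1-yl in place of pyrrolidin-1-yl on a thiocarbonyl carbon, in the presence of chloro, shows an at least 1.0-fold higher number from compound 1 to compound 4 (0.00 log units; that floor lies within the scatter), and this step cannot be read any further, so the compounds shown do not tell how these two rings rank on the chlorinated core. On these data alone, it also remains open whether a fluoro or a methoxy group on the same aromatic carbon would bring a similar loss, or whether morpholin-4-yl in place of piperidin-1-yl would change the number of compound 2.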